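From propyl to 2-hydroxyethyl in compound 4

The source may hold more compounds than are shown below. What is called first, only, known or untested is meant among the compounds shown, and "the series" means these compounds.

In a functional assay on Raji cells (Homo sapiens) for antiproliferative activity, read by MTT assay, with a stated time of 48 h (a higher number here means a weaker inhibitor, a lower number a stronger inhibitor), compound 3 (`CCCn1c(N)c(-c2nc3ccccc3[nH]2)c2nc(C#N)c(C#N)nc21`) reads > 50000 nM and this is a limit, not a number. Compound 2 (`CN1CCN(CCn2c(N)c(-c3nc4ccccc4[nH]3)c3nc(C#N)c(C#N)nc32)CC1`) reads > 50000 nM and this too is a limit. Only compound 1 (`CCN(CC)CCn1c(N)c(-c2nc3ccccc3[nH]2)c2nc(C#N)c(C#N)nc21`) gives a true number, with 8950 nM as its reading. Losing diethylamino gave an at least 5.5-fold higher number from compound 1 to compound 3 (0.74 log units; beyond the scatter) with methyl in its place and an at least 5.5-fold higher number from compound 1 to compound 2 (0.74 log units; beyond the scatter) with 4-methylpiperazin-1-yl in its place, and the remaining pair shows only a step that the two limits leave unreadable from compound 2 to compound 3 and nothing more. Compound 4 (`N#Cc1nc2c(-c3nc4ccccc4[nH]3)c(N)n(CCO)c2nc1C#N`) has hydroxy in place of methyl on a saturated chain carbon, two bonds along the chain from an aromatic nitrogen. Hydroxy is untested, but compound 4 also lacks the diethylamino whose loss gave an at least 5.5-fold higher number from compound 1 to compound 3 (0.74 log units; beyond the scatter) in the nearest comparison. The expected change is an at least 1.1-fold lower number from compound 3 to compound 4 (0.04 log units; that floor lies within the scatter) and so none beyond the scatter. Compound 4 is estimated at 45000 nM in this assay with a range from 15000 nM to 100000 nM expected.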

Compound 4, half-maximal inhibitory concentration: 5520 nM
For compound 4 the middle estimate is 8.2-fold (0.91 log units) above the measured one; measured number below the stated range.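

In this assay, hydroxy in place of methyl at this position gives an at least 9.0-fold lower number from compound 3 to compound 4 (0.95 log units; beyond the scatter), and hydroxy in place of 4-methylpiperazin-1-yl gives an at least 9.0-fold lower number from compound 2 to compound 4 (0.95 log units; beyond the scatter). For the compounds shown here, the readings of compound 2 and compound 3 are limits, not numbers, so both steps are floors: the limit of > 50000 nM in this assay, at which 2 of the 4 values shown sit. Diethylamino is therefore not the only group here that reads short of that limit, since hydroxy in its place gives a 1.6-fold lower number from compound 1 to compound 4 (0.21 log units; within the scatter). Going by these compounds, whether a primary amine, a carboxylic acid or a longer chain ending in hydroxy would read like compound 4 stays open.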